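A few compounds are considered here, and "the series" means these few. Any claim that something is new, unique, unknown or untested is made for them only; others in the source may bear on it.

Compound 1 `COc1ccccc1-c1cccc2nc(Nc3cc(OC)c(OC)c(OC)c3)oc12` is the stronger of the two measured compounds in an assay on BAF cells for inhibition of ribosomal protein S6 kinase alpha-2 (Mus musculus) (a higher number here means a weaker inhibitor, a lower number a stronger inhibitor), where compound 1 gives 5700 nM. Compound 2 `COc1cc(Nc2nc3cccc(-c4c(F)cccc4OC(C)C)c3o2)cc(OC)c1OC` carries a different aryl group on the same core. In this assay compound 2 reaches only the limit of the assay, > 20000 nM, and no number. The step of an at least 3.5-fold higher number from compound 1 to compound 2 (0.54 log units; beyond the scatter) is thus known only as a lower bound because the limit of > 20000 nM in this assay, at which 1 of the 2 values shown sits, caps it.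

Compound 3 `COc1cc(Nc2nc3cccc(-c4cccc5cn[nH]c45)c3o2)cc(OC)c1OC` differs from compound 2 by a group of 9 heavy atoms (7 carbon, 2 nitrogen; one five-membered aromatic ring with 2 hetero atoms, one six-membered aromatic ring of carbon only) in place of a group of 11 heavy atoms (9 carbon, 1 oxygen, 1 fluorine; one six-membered aromatic ring of carbon only), on an aromatic carbon. Among the measured compounds shown here, the one measured step bears on this change only indirectly: it shows that exchanging the aryl group on this carbon can shift the number by an at least 3.5-fold higher number from compound 1 to compound 2 (0.54 log units; beyond the scatter), in the weakening direction. With the group that enters, the 1H-indazol-7-yl, being smaller than what leaves and bringing a hydrogen-bond donor, a partial return toward the region of compound 1 is expected rather than a further loss. The estimated step is an at least 5.0-fold lower number from compound 2 to compound 3 (0.69 log units; beyond the scatter), toward stronger inhibition. Compound 3 is accordingly expected at about 4000 nM, within a range from 800 nM to 20000 nM.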

Compound 3, half-maximal inhibitory concentration: 5700 nM
Estimate against measurement, compound 3: 1.4-fold (0.15 log units) below; the range from low to high includes it.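

In this assay, the exchange of 2-methoxyphenyl for 1H-indazol-7-yl on this aromatic carbon gives no change at the digits printed from compound 1 to compound 3 (within the scatter), so a group with a second, five-membered aromatic ring cannot be told apart from the single-ring group of the first compound. Against the larger group that carries fluorine, the same 1H-indazol-7-yl gives an at least 3.5-fold lower number from compound 2 to compound 3 (0.54 log units; beyond the scatter), which shows that the loss seen earlier at this position can be recovered by changing the group on the same carbon. Compound 2 stands at a limit of the assay and not at a number, and the size of this recovery is a lower bound only because of that limit: the limit of > 20000 nM in this assay, at which 1 of the 3 values shown sits.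

The compounds shown leave open whether the hydrogen-bond donor counted for the 1H-indazol-7-yl plays any part in this result, a question that a methyl group in place of the hydrogen on its ring nitrogen would address. They also leave open whether any other group on this carbon, such as a phenyl bearing an amine or a carboxylic acid, would move the number beyond the level shared by compound 1 and compound 3.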